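The source may hold more compounds than are shown below. What is called first, only, known or untested is meant among the compounds shown, and "the series" means these compounds.

Working notes on the series, continuing with the benzylpiperidine amides.

Compound 2 `COc1cccc(CN2CCC(C(=O)Nc3cc(Cl)c(N)cc3OC)CC2)c1` carries a 3-methoxybenzyl group on the piperidine nitrogen. In a functional assay on the whole organism for antagonist activity, with Mus musculus as the target (on this read-out lower numbers stand for an effect already at smaller amounts and higher numbers for an effect only at larger amounts of compound), compound 2 gives only a limit, > 4 mg/kg. Its nearest measured relative is compound 1 `COc1cc(N)c(Cl)cc1NC(=O)C1CCN(CC2CC2)CC1`, which bears cyclopropylmethyl at the same nitrogen. In this assay compound 1 likewise gives only a limit, > 10 mg/kg. Among the measured compounds shown here, the step from these two is a step that the two limits leave unreadable from compound 1 to compound 2, so no size can be drawn from it; the only evidence on hand is the limit of > 10 mg/kg in this assay, at which 1 of the 2 values shown sits, and (the limit of > 4 mg/kg in this assay, at which 1 of the 2 values shown sits), both limits and neither a number.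

Compound 3 `COc1cc(N)c(Cl)cc1NC(=O)C1CCN(Cc2ccc(F)cc2)CC1` differs from compound 2 by 4-fluorophenyl in place of 3-methoxyphenyl on a saturated chain carbon bound to an amine nitrogen in a ring. For the measured compounds named here, no measured step bears directly on this change; the one step, from compound 1 to compound 2, is itself unreadable, so no direction or size beyond the scatter can be predicted for this assay. On that basis compound 3 is expected to sit near the limits already seen, estimated at 10 mg/kg with a range from 3 mg/kg to 30 mg/kg. The implied step that the limit leaves unreadable from compound 2 to compound 3 is an expectation only and may again end as a limit rather than a number.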

Compound 3, dose for half-maximal effect: 0.6 mg/kg
Compound 3: middle estimate off by 17-fold (1.22 log units), on the high side; measured number below the stated range.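

In this assay, the group on a saturated chain carbon bound to an amine nitrogen in a ring now proves to matter: 4-fluorophenyl in place of 3-methoxyphenyl gives an at least 6.6-fold lower number from compound 2 to compound 3 (0.82 log units; beyond the scatter), a readable change that the earlier pair could not provide. The same group in place of cyclopropyl gives an at least 16-fold lower number from compound 1 to compound 3 (1.22 log units; beyond the scatter), which makes compound 3 the only one of the three with a number rather than a limit, while the step between the other two compounds cannot be read. The values show the size of these changes only, and nothing measured here points to a cause for them.

Since 3-methoxyphenyl and 4-fluorophenyl differ both in the substituent and in where it sits, the compounds shown do not separate the gain of fluorine, the loss of methoxy and the change of ring position. Unsubstituted phenyl, 3-fluorophenyl and 4-methoxyphenyl at the same place would pull these apart, and the real sizes of the two steps stay open as long as compound 1 and compound 2 stand as limits.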